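This account rests on a few compounds, and the source may have more. Where it says the series, first, only, none or still open, it means among the compounds named here.

Compound 1 `COC(=O)CNC1=CS(=O)(=O)O[C@@]12[C@@H](CO[Si](C)(C)C(C)(C)C)O[C@@H](n1cc(C)c(=O)n(C)c1=O)[C@@H]2O[Si](C)(C)C(C)(C)C` gives 105000 nM
Compound 2 `C=C(C)C(=O)NC(=O)NC1=CS(=O)(=O)O[C@@]12[C@@H](CO[Si](C)(C)C(C)(C)C)O[C@@H](n1cc(C)c(=O)n(C)c1=O)[C@@H]2O[Si](C)(C)C(C)(C)C` gives 1190 nM
Compound 3 `COC(=O)C(=O)CNC1=CS(=O)(=O)O[C@@]12[C@@H](CO[Si](C)(C)C(C)(C)C)O[C@@H](n1cc(C)c(=O)n(C)c1=O)[C@@H]2O[Si](C)(C)C(C)(C)C` gives 10300 nM

These values come from a functional assay on MT4 cells (Homo sapiens); on this read-out lower numbers stand for higher toxicity in this test and higher numbers for lower toxicity in this test. Compound 3 stands second highest of the three, with compound 2 lower and compound 1 higher. Compound 4 `Cc1cn([C@@H]2O[C@H](CO[Si](C)(C)C(C)(C)C)[C@@]3(OS(=O)(=O)C=C3NCC(=O)C(N)=O)[C@H]2O[Si](C)(C)C(C)(C)C)c(=O)n(C)c1=O` differs from compound 3 by amino in place of methoxy on a carbonyl carbon. For the measured compounds named here, no measured step makes this exact exchange. The nearest is a 10-fold lower number from compound 1 to compound 3 (1.01 log units; beyond the scatter), also made on a carbonyl carbon, while an 8.7-fold higher number from compound 2 to compound 3 (0.94 log units; beyond the scatter) is a broader change. Neither fixes the direction here, so the expected step in this assay is smaller than these, tentatively upward: a 2.4-fold higher number from compound 3 to compound 4 (0.39 log units; beyond the scatter). For compound 4 the estimated value is 25000 nM, with an expected range from 5000 nM to 100000 nM.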

Compound 4, half-maximal cytotoxic concentration: 9590 nM
The estimate for compound 4 lay 2.6-fold (0.42 log units) above the measured number, and the stated range covers the measured number.
By their numbers in this assay, from the lowest: compound 2; then compounds 4 and 3 (each within the scatter of the next); then compound 1.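

In this assay, amino in place of methoxy on this carbonyl carbon gives a 1.1-fold lower number from compound 3 to compound 4 (0.03 log units; within the scatter), so this exchange makes no difference beyond the scatter. The gaps to the other two compounds therefore remain, at an 8.1-fold higher number from compound 2 to compound 4 (0.91 log units; beyond the scatter) and an 11-fold lower number from compound 1 to compound 4 (1.04 log units; beyond the scatter). Nothing measured here accounts for these steps. As far as these compounds go, it remains open whether hydroxy, methylamino or dimethylamino on the same carbonyl carbon would also stay within the scatter of compound 3 .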